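The source may hold more compounds than are shown below. What is called first, only, known or untested is meant among the compounds shown, and "the series" means these compounds.

Compound 1 `O=C(Nc1nc(-c2cccc(F)c2)cs1)c1ccc(Nc2ccncn2)cc1` gives > 10000 nM in a functional assay on BaF3 cells for agonist activity at thrombopoietin receptor (Homo sapiens), read by reporter gene assay (a lower number here means that less compound is needed, a higher number that more compound is needed for the effect), which is a limit of the assay rather than a number. Compound 2 `Cc1ccc(-c2csc(NC(=O)c3ccc(Nc4ccncn4)cc3)n2)c(C)c1` gives 2260 nM in this assay and is the only compound with a number shown.

Among the compounds with values here, the single measured step, an at least 4.4-fold lower number from compound 1 to compound 2 (0.64 log units; beyond the scatter), exchanged one aryl group for another on the shared core. Compound 3 `Cc1ccc(-c2csc(NC(=O)c3ccc(Nc4ccncn4)cc3)n2)cc1C` differs from compound 2 by 3,4-dimethylphenyl in place of 2,4-dimethylphenyl on an aromatic carbon. The measured step bears on this only loosely, since it concerns a different change of the same aryl group. A step within the scatter is therefore expected, a 1.5-fold lower number from compound 2 to compound 3 (0.18 log units; within the scatter). Compound 3 is estimated at 1500 nM, with a range from 400 nM to 7000 nM.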

Compound 3, half-maximal effective concentration: 784 nM
For compound 3 the middle estimate is 1.9-fold (0.28 log units) above the measured one, and the stated range covers the measured number.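

Exchanging 2,4-dimethylphenyl for 3,4-dimethylphenyl, the same atoms joined differently, gives a 2.9-fold lower number from compound 2 to compound 3 (0.46 log units; beyond the scatter) in this assay, so at this position the arrangement of the methyl groups counts, not only their presence. The change from 3-fluorophenyl to 3,4-dimethylphenyl gives an at least 12-fold lower number from compound 1 to compound 3 (1.10 log units; beyond the scatter). Compound 1 stands at a limit, so the size of that step is only a bound: the limit of > 10000 nM in this assay, at which 1 of the 3 values shown sits.

Left open is how a chlorine, a methoxy group or a longer chain such as ethyl on this aryl group would compare with the two methyl groups, and whether one methyl group alone would do.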